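Chalcone anilides: ring swap on the amide carbonyl

The source may report more compounds than this note shows. Statements on the series, on what has been measured and on what is new or still open speak of the compounds shown alone.

Measured so far:
compound 1 `O=C(/C=C/c1ccccc1)c1ccc(NC(=O)c2cccs2)cc1` — 35000 nM
compound 2 `O=C(/C=C/c1ccccc1)c1ccc(NC(=O)c2ccccc2)cc1` — 46000 nM
compound 3 `O=C(/C=C/c1cccc([N+](=O)[O-])c1)c1ccc(NC(=O)c2cccs2)cc1` — 11000 nM

All three have been run in a functional assay on DLD-1 cells (Homo sapiens) for cytotoxicity, read by resazurin assay, with a stated time of 48 h; on this read-out higher numbers stand for an effect only at larger amounts of compound and lower numbers for an effect already at smaller amounts. Compound 1 and compound 2 differ only by phenyl in place of thiophen-2-yl on a carbonyl carbon. That change gave a 1.3-fold higher number from compound 1 to compound 2 (0.12 log units; within the scatter), so the two numbers cannot be told apart. Compound 3 stands apart from compound 1 by nitro in place of hydrogen on an aromatic carbon, and that change gave a 3.2-fold lower number from compound 1 to compound 3 (0.50 log units; beyond the scatter); compound 3 holds the lowest number of the three, and its steps to compound 1 and to compound 2 are both beyond the scatter.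

Compound 4 `O=C(/C=C/c1cccc([N+](=O)[O-])c1)c1ccc(NC(=O)c2ccccc2)cc1` has not been measured. It differs from compound 3 by phenyl in place of thiophen-2-yl on a carbonyl carbon, which is the same kind of change as that from compound 1 to compound 2, and the surroundings of the place are the same in both cases. The two cores differ by what is set out above for compound 1 and compound 3.

The step expected from compound 3 to compound 4 is a 1.3-fold higher number from compound 3 to compound 4 (0.10 log units; within the scatter), close to the earlier one, because a 1.3-fold higher number from compound 1 to compound 2 (0.12 log units; within the scatter) lay within the scatter. Compound 4 is therefore estimated at 14000 nM in this assay. Going by the values given here, a range of 7000 nM to 30000 nM is expected for compound 4, resting on the single earlier pair and on the value of compound 3.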

Compound 4, half-maximal effective concentration: > 100000 nM
Compound 4: only a limit was reported (the forecaster's own chance of this, stated with the estimate: 5%); middle value at least 7.1-fold (0.85 log units) away from the limit.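

Phenyl in place of thiophen-2-yl on a carbonyl carbon gave an at least 9.0-fold higher number from compound 3 to compound 4 (0.95 log units; beyond the scatter) in this assay, so this change does not carry unchanged from the core of compound 1 to the nitro-bearing core: the same change on two cores in this assay, a 1.3-fold higher number (0.12 log units; within the scatter) from compound 1 to compound 2 and an at least 9.0-fold higher number (0.95 log units; beyond the scatter) from compound 3 to compound 4, at least 6.9-fold (0.83 log units) apart, beyond the scatter of two such steps

Nitro in place of hydrogen on an aromatic carbon gave an at least 2.1-fold higher number from compound 2 to compound 4 (0.33 log units; beyond the scatter), which runs opposite to its earlier step on the thiophen-2-yl side, so the two changes do not add up independently in this set: the same change on two cores in this assay, a 3.2-fold lower number (0.50 log units; beyond the scatter) from compound 1 to compound 3 and an at least 2.1-fold higher number (0.33 log units; beyond the scatter) from compound 2 to compound 4, at least 6.9-fold (0.83 log units) apart, beyond the scatter of two such steps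

Compound 4 gives > 100000 nM, which is a limit of the assay and not a number, so both new steps fix only a smallest possible size, and the result rests on a single set of four compounds and shows neither a mechanism nor a rule for the wider series: the limit of > 100000 nM in this assay, at which 1 of the 4 values shown sits.

Going by these compounds, it remains open whether other rings on the carbonyl, such as furan-2-yl or pyridin-2-yl, behave like thiophen-2-yl or like phenyl once nitro is present, and whether a nitrile or an amine in place of nitro gives the same dependence on the core. On these data alone, the true size of the gap also stays open while compound 4 is known only as a limit.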